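Swapping the Amide Aryl Group: Expected Effect on Kinase Inhibition

The compounds below may be only part of what the source reports. "The series", "measured", "known", "first", "only" and "open" are said of these compounds alone.

compound 1 `O=C(COc1ccc2c(=O)ccoc2c1)Nc1cccc(NC(=O)c2ccc(OC(F)(F)F)cc2)c1`: 869 nM
compound 2 `Cc1nc(C(=O)Nc2cccc(NC(=O)COc3ccc4c(=O)ccoc4c3)c2)cs1`: 473 nM

Both values come from an assay on isolated protein for inhibition of Rho-associated protein kinase 1 (Homo sapiens), read by scintillation counting, radiometric assay and 33P incorporation, with a stated time of 40 min, in the presence of a further agent that is not named here; a higher number here means a weaker inhibitor, a lower number a stronger inhibitor. The two numbers lie within the scatter of each other, so compound 2 cannot be told apart from compound 1 on these data. Compound 3 `O=C(COc1ccc2c(=O)ccoc2c1)Nc1cccc(NC(=O)c2ccc(C(=O)O)cc2)c1` differs from compound 2 by 4-carboxyphenyl in place of 2-methyl-1,3-thiazol-4-yl on a carbonyl carbon. Among the measured compounds shown here, the only step that bears on this is the earlier swap on the same carbonyl carbon, a 1.8-fold lower number from compound 1 to compound 2 (0.26 log units; within the scatter), which stayed within the scatter. The expected step is therefore small, a 1.3-fold higher number from compound 2 to compound 3 (0.10 log units; within the scatter), with no clear direction. Compound 3 is estimated at 600 nM, ranging from 250 nM to 1500 nM.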

Compound 3, half-maximal inhibitory concentration: 6890 nM
Estimate against measurement, compound 3: 11-fold (1.06 log units) below; measured number outside the range, above it.
By their numbers in this assay, from the lowest: compounds 2 and 1 (each within the scatter of the next); then compound 3.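

Among the compounds shown here, the first swap on this carbonyl carbon hinted at tolerance, but this position does respond to the group placed on it: 4-carboxyphenyl brings a 15-fold higher number from compound 2 to compound 3 (1.16 log units; beyond the scatter) and marks a large loss. The change is also felt with the phenyl ring kept, since carboxy in place of trifluoromethoxy on an aromatic carbon brings a 7.9-fold higher number from compound 1 to compound 3 (0.90 log units; beyond the scatter) and is a modest loss. Nothing available here gives a reason for either loss.

On these data alone, whether the carboxylic acid itself matters stays open. A methyl ester or a primary amide in its place would show whether the loss follows that group.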